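This account rests on a few compounds, and the source may have more. Where it says the series, first, only, none or still open, it means among the compounds named here.

Measured compounds:
Compound 1 `COc1ccc(/C=C/C(=O)c2ccc(OC)c3c2OC(C)(C)C=C3)cc1OCC=C(C)C` — in a functional assay on HepG2 cells (Homo sapiens) for cytotoxicity, read by MTT assay (on this read-out lower numbers stand for stronger inhibition and higher numbers for weaker inhibition), compound 1 gives > 10000 nM, which is a limit of the assay and not a number.
Compound 2 `C#CCOc1cc(/C=C/C(=O)c2ccc(OC)c3c2OC(C)(C)C=C3)ccc1OC` — in this assay compound 2 gives > 10000 nM, again a limit rather than a number.
Compound 3 `C=CC(=O)Oc1cc(/C=C/C(=O)c2ccc(OC)c3c2OC(C)(C)C=C3)ccc1OC` — in this assay compound 3 gives 160 nM.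

For the measured compounds named here, compound 3 therefore holds the only number among the three; the other two values are covered by the limit of > 10000 nM in this assay, at which 2 of the 3 values shown sit. Compound 4 `COc1ccc(/C=C/C(=O)c2ccc(OC)c3c2OC(C)(C)C=C3)cc1OS(=O)(=O)Cc1ccccc1` differs from compound 3 in one place: benzylsulfonyl in place of vinylcarbonyl on an oxygen on an aromatic ring. Going by the values given here, no measured step involves benzylsulfonyl. The steps that lead into compound 3 bear on it indirectly: an at least 62-fold lower number from compound 1 to compound 3 (1.79 log units; beyond the scatter) and an at least 62-fold lower number from compound 2 to compound 3 (1.79 log units; beyond the scatter), both large drops when vinylcarbonyl enters. Compound 4 gives up that vinylcarbonyl, so a large rise in this assay is expected, a 31-fold higher number from compound 3 to compound 4 (1.49 log units; beyond the scatter), possibly back to a limit. Compound 4 is accordingly estimated at 5000 nM, within 1000 nM to 20000 nM.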

Compound 4, half-maximal inhibitory concentration: > 10000 nM
Compound 4 ended at the assay's limit; the forecaster's own chance of this, stated with the estimate: 40%; middle value at least 2.0-fold (0.30 log units) away from the limit.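

At this oxygen on an aromatic ring, benzylsulfonyl in place of vinylcarbonyl gives an at least 62-fold higher number from compound 3 to compound 4 (1.79 log units; beyond the scatter) in this assay. The drop seen earlier on entering vinylcarbonyl thus has its counterpart in a rise on removing it, and a group with a sulfur and an aromatic ring does no better than the two earlier groups. The steps from compound 1 and compound 2 to compound 4 cannot be read: the limit of > 10000 nM in this assay, at which 3 of the 4 values shown sit.

The compounds shown leave open whether the carbonyl or the carbon-carbon double bond of vinylcarbonyl matters. An acetyl group on this oxygen would separate the two.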